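The source may report more compounds than this note shows. Statements on the series, on what has been measured and on what is new or still open speak of the compounds shown alone.

Measured so far in a functional assay on MDA-MB-231 cells (Homo sapiens) for antiproliferative activity, read by MTT assay, with a stated time of 72 h; a lower number here means a stronger inhibitor, a higher number a weaker inhibitor:
- compound 1 `CC(C)c1cccc(NC(=O)CCc2cccc3c2B(O)OC3)c1`: 1600 nM
- compound 2 `C#Cc1cccc(NC(=O)CCc2cccc3c2B(O)OC3)c1`: 1600 nM
- compound 3 `O=C(CCc1cccc2c1B(O)OC2)Nc1cccc(-c2cccc(C(F)(F)F)c2)c1`: 410 nM

Compound 3 has the lowest number of the three, 410 nM, and so is the strongest inhibitor of this set. The next compound, compound 4 `N#Cc1cccc(-c2cccc(NC(=O)CCc3cccc4c3B(O)OC4)c2)c1`, differs from it by one change: cyano in place of trifluoromethyl on an aromatic carbon. In words, cyano sits in place of trifluoromethyl, so 3-(trifluoromethyl)phenyl becomes 3-cyanophenyl.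

Among the measured compounds shown here, no measured step swaps this group directly, so the evidence is indirect. Putting 3-(trifluoromethyl)phenyl in place of isopropyl gave a 3.9-fold lower number from compound 1 to compound 3 (0.59 log units; beyond the scatter), and putting it in place of ethynyl gave a 3.9-fold lower number from compound 2 to compound 3 (0.59 log units; beyond the scatter). Both steps are modest but beyond the scatter. Compound 4 keeps a phenyl ring at that place, so most of that gain is expected to remain. For the measured compounds named here, the one swap of a group for another on the same carbon, ethynyl for isopropyl, gave no change at the digits printed from compound 1 to compound 2 (within the scatter), within the scatter.

The expected result is a small move towards a higher number, not beyond the scatter: a 1.2-fold higher number from compound 3 to compound 4 (0.09 log units; within the scatter). In this assay, the estimate for compound 4 is 500 nM, with an expected range of 190 nM to 1300 nM.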

Compound 4, half-maximal inhibitory concentration: 110 nM
The estimate for compound 4 lay 4.5-fold (0.66 log units) above the measured number; the whole stated range lies above it.
By their numbers in this assay, from the lowest: compound 4; then compound 3; then compounds 1 and 2 (each within the scatter of the next).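

In this assay, among the compounds shown here, the earlier compounds showed only that a substituted phenyl ring at this place gave a lower number than isopropyl or ethynyl. Cyano in place of trifluoromethyl now gives a 3.7-fold lower number from compound 3 to compound 4 (0.57 log units; beyond the scatter) and so shows that the small group carried on that ring also counts, not just the presence of the ring. Against the simple groups, 3-cyanophenyl gives a 15-fold lower number from compound 2 to compound 4 (1.16 log units; beyond the scatter) and a 15-fold lower number from compound 1 to compound 4 (1.16 log units; beyond the scatter) in two large steps, and nothing measured here bears on why cyano outperforms trifluoromethyl.

Going by these compounds, only these two groups on the ring can be compared, so it remains open whether a methoxy group, an amine or a carboxylic acid would match cyano. On these data alone, how cyano would behave on a different carbon of that ring also remains open.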